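From methyl to sec-butyl: the step to compound 4

The compounds below may be only part of what the source reports. "The series", "measured", "known", "first", "only" and "open" are said of these compounds alone.

Compound 1 (`COC(=O)CNC(=O)c1ccc(Oc2nc3ccccc3nc2NC(C)(C)C)cc1`): > 50000 nM (a limit)
Compound 2 (`CC(C)(C)Nc1nc2ccccc2nc1Oc1ccc(C(=O)NCC(=O)O)cc1`): > 50000 nM (a limit)
Compound 3 (`C[C@H](NC(=O)c1ccc(Oc2nc3ccccc3nc2NC(C)(C)C)cc1)C(=O)O`): 29400 nM

Among the compounds with values here, compound 3 gives 29400 nM in a functional assay on MCF7 cells (Homo sapiens) for antiproliferative activity, read by MTT assay, with a stated time of 48 h (a higher number here means a weaker inhibitor, a lower number a stronger inhibitor), and holds the only true number so far. Compound 1 and compound 2 give no number and stand at the limit of > 50000 nM in this assay, at which 2 of the 3 values shown sit, instead.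

Compound 4 (`CC[C@@H](C)[C@H](NC(=O)c1ccc(Oc2nc3ccccc3nc2NC(C)(C)C)cc1)C(=O)O`) differs from compound 3 in one place. The difference is sec-butyl in place of methyl on a saturated chain carbon bound to an amide-type nitrogen and a carbonyl carbon and reads, in words, sec-butyl in place of methyl on a saturated chain carbon bound to an amide-type nitrogen and a carbonyl carbon.

The nearest measured change sits on that same carbon, where methyl replaces hydrogen: an at least 1.7-fold lower number from compound 2 to compound 3 (0.23 log units; that floor lies within the scatter) is what it shows. The step of an at least 1.7-fold lower number from compound 1 to compound 3 (0.23 log units; that floor lies within the scatter) also alters this group, while a step that the two limits leave unreadable from compound 1 to compound 2 offers no size to work with. Both readable steps are only floors, and both lie within the scatter, so in this assay no more than a small downward drift is expected. The expected outcome is a 1.5-fold lower number from compound 3 to compound 4 (0.17 log units; within the scatter) and no step beyond the scatter. Compound 4 is estimated at 20000 nM with an expected range from 7000 nM up to 50000 nM as its upper end.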

Compound 4, half-maximal inhibitory concentration: 11400 nM
Compound 4: the middle estimate sits 1.8-fold (0.24 log units) above what was measured; low and high end bracket the measured number.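

Within the data shown here, putting sec-butyl in place of methyl on the saturated chain carbon bound to an amide-type nitrogen and a carbonyl carbon gives a 2.6-fold lower number from compound 3 to compound 4 (0.41 log units; beyond the scatter), the first step in this assay between two true numbers. Placing sec-butyl on that carbon in place of hydrogen gives an at least 4.3-fold lower number from compound 2 to compound 4 (0.64 log units; beyond the scatter), and exchanging the whole (methoxycarbonyl)methyl for 1-carboxy-2-methylbutyl on the amide-type nitrogen gives an at least 4.3-fold lower number from compound 1 to compound 4 (0.64 log units; beyond the scatter), so changes at this place now reach beyond the scatter, which the earlier readable steps did not. These last two steps are floors and not full sizes, since compound 1 and compound 2 each stand at a limit of the assay: the limit of > 50000 nM in this assay, at which 2 of the 4 values shown sit.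

Only methyl and sec-butyl carry true numbers on this carbon, so one step cannot tell whether the number would keep falling with a longer chain, or with a benzyl group or an isopropyl group in the same place. On these data alone, it also stays open whether the defined stereocentre of the sec-butyl matters, and whether the ester of compound 4 or an amide in place of its carboxylic acid would hold the gain.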